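Adding a chloro group to the phenyl ring of compound 1

The compounds below may be only part of what the source reports. "The series", "measured", "known", "first", "only" and "open" are said of these compounds alone.

Measured compounds:
- compound 1, `NS(=O)(=O)c1ccc2nc(N3N=C(c4ccc(Cl)cc4)CC3c3ccccc3)sc2c1`: 68.3%
- compound 2, `NS(=O)(=O)c1ccc2nc(N3N=C(c4ccc(Br)cc4)CC3c3ccc(F)cc3)sc2c1`: 14%
- compound 3, `COc1ccc(C2CC(c3ccc(Br)cc3)=NN2c2nc3ccc(S(N)(=O)=O)cc3s2)cc1`: 14%

In a functional assay on the whole organism (strain Wistar) for inhibition, with Rattus norvegicus as the target, read by paw edema, with stated times of 1 h and 5 h, at a dose of 20 mg/kg by the oral route (on this read-out higher numbers stand for more inhibition at the one dose given (going by the name of the read-out) and lower numbers for less inhibition), compound 1 gives 68.3%, the highest of the three numbers, and both other compounds lie well beyond the scatter below it. Compound 4, `NS(=O)(=O)c1ccc2nc(N3N=C(c4ccc(Cl)cc4)CC3c3ccc(Cl)cc3)sc2c1`, differs from compound 1 in one place: chloro in place of hydrogen on an aromatic carbon. Within the data shown here, no measured step is of the same kind. Among the measured compounds shown here, the only step available, no change at the digits printed from compound 2 to compound 3 (within the scatter), exchanges one group for another on that same aromatic carbon and so does not tell what happens when hydrogen there gives way to a group. Compounds 2 and 3, which both carry a group on that carbon, sit far below compound 1, but they also carry bromo where compound 1 has chloro, so the two differences cannot be separated. Compound 4 is therefore expected to fall somewhere between those readings, with a step of a number 26.3 percentage points lower from compound 1 to compound 4 (beyond the scatter) estimated, giving an estimate of 42% in this assay, between 12% and 72%.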

Compound 4, a percentage reported as inhibition, in the whole organism at one dose (the size of the read-out at that dose, not a potency): 14%
Estimate against measurement, compound 4: 28 percentage points above; the range from low to high includes it.
By their numbers in this assay, from the lowest: compounds 2, 3 and 4 (each within the scatter of the next); then compound 1.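

In this assay the change from phenyl to 4-chlorophenyl gives a number 54.3 percentage points lower from compound 1 to compound 4 (beyond the scatter) as a large loss of inhibition at the one dose tested. Among these compounds, this is the first measured step in which hydrogen on this aromatic carbon gives way to a group while the rest of the molecule stays the same, so the loss cannot come from any other part of the structure, whereas compounds 2 and 3 also carry bromo where compound 1 has chloro. No measurement shown here explains the loss.

As far as these compounds go, whether a smaller change at this carbon, such as a methyl, a hydroxyl or an amine in place of hydrogen, would keep more of the inhibition remains open. Also open, from the compounds shown here alone, is whether a bromo in place of the chloro on the other ring would keep the reading of compound 1 when this carbon bears hydrogen.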